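Changing the Aryl Group on the Amide

The source may hold more compounds than are shown below. What is called first, only, known or untested is meant among the compounds shown, and "the series" means these compounds.

In a functional assay on MCF7 cells (Homo sapiens) for inhibition, read by MTT assay (on this read-out lower numbers stand for stronger inhibition and higher numbers for weaker inhibition), compound 1 `COc1cc2ncnc(Nc3ccc(NC(=O)c4ccccc4OC)cc3)c2cc1OC` reports only a limit, > 100000 nM. Compound 2 `COc1cc2ncnc(Nc3ccc(NC(=O)c4cccc(F)c4)cc3)c2cc1OC` gives 13600 nM, and compound 3 `COc1cc2ncnc(Nc3ccc(NC(=O)c4ccc(Br)cc4)cc3)c2cc1OC` gives 43000 nM, the higher of these two actual numbers. Compound 4 `COc1cc2ncnc(Nc3ccc(NC(=O)c4c(F)cccc4F)cc3)c2cc1OC` carries 2,6-difluorophenyl in place of 4-bromophenyl on a carbonyl carbon. Three measured steps change this same place, each beyond the scatter: an at least 7.3-fold lower number from compound 1 to compound 2 (0.86 log units; beyond the scatter), an at least 2.3-fold lower number from compound 1 to compound 3 (0.36 log units; beyond the scatter) and a 3.2-fold higher number from compound 2 to compound 3 (0.50 log units; beyond the scatter). Their guidance is mixed, since compound 4 has fluorine like compound 2 at 13600 nM, but a group in the 2 position like compound 1. The expected change is therefore small, a 1.2-fold lower number from compound 3 to compound 4 (0.09 log units; within the scatter), with no shift beyond the scatter anticipated. For compound 4 the estimated value is 35000 nM, with an expected range of 10000 nM to 100000 nM.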

Compound 4, half-maximal inhibitory concentration: 24000 nM
The estimate for compound 4 lay 1.5-fold (0.16 log units) above the measured number, and the stated range covers the measured number.
By their numbers in this assay, from the lowest: compounds 2, 4 and 3 (each within the scatter of the next, the first and the last beyond it). At a limit, above all of these: compound 1.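

Compound 4 cannot be separated from its two nearest neighbours, a 1.8-fold lower number from compound 3 to compound 4 (0.25 log units; within the scatter) and a 1.8-fold higher number from compound 2 to compound 4 (0.25 log units; within the scatter), so 2,6-difluorophenyl on this carbonyl carbon performs like 4-bromophenyl and 3-fluorophenyl. The step from 2-methoxyphenyl is clearer, an at least 4.1-fold lower number from compound 1 to compound 4 (0.61 log units; beyond the scatter), so the weak result of compound 1 does not extend to 2,6-difluorophenyl. That comparison rests on a limit for compound 1: the limit of > 100000 nM in this assay, at which 1 of the 4 values shown sits.

All four groups shown are substituted phenyl rings. On these data alone, whether an amine, a carboxylic acid or a longer chain at this carbonyl carbon would give a clearly lower number than compound 2 remains open.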